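One Group Exchanged in a Growth Inhibitor

The source may hold more compounds than are shown below. What is called first, only, known or untested is meant among the compounds shown, and "the series" means these compounds.

Within the data shown here, only two compounds have been measured so far in a functional assay on DU-145 cells (Homo sapiens) for inhibition, read by trypan blue exclusion, with a stated time of 96 h; a lower number here means a stronger inhibitor of growth, a higher number a weaker inhibitor of growth. Compound 1 (`O=C(/C(=C\c1ccc(O)cc1O)Sc1ccc(Br)cc1)c1ccc(Cl)cc1`) gives 50000 nM, while compound 2 (`O=C(/C(=C\c1ccc(O)c([N+](=O)[O-])c1)SCc1ccc(Cl)cc1)c1ccc(Cl)cc1`) gives 10000 nM. Compound 2 therefore has the lower number of the two and is the stronger inhibitor, by a gap beyond the usual scatter. These two compounds differ in more than one place, so their gap cannot be assigned to any single change. Compound 3 (`O=C(/C(=C\c1ccc(O)cc1O)SCc1ccc(Cl)cc1)c1ccc(Cl)cc1`) differs from compound 2 in one place: 2,4-dihydroxyphenyl in place of 4-hydroxy-3-nitrophenyl on a double-bonded chain carbon bound to a double-bonded chain carbon. The incoming 2,4-dihydroxyphenyl also appears on compound 1, which gives 50000 nM, so weaker inhibition is expected, although this single comparison is thin evidence. The expected change is a 2.0-fold higher number from compound 2 to compound 3 (0.30 log units; within the scatter), toward a higher number. For compound 3, the estimated value is 20000 nM, with an expected range of 6000 nM to 60000 nM.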

Compound 3, concentration for 50% growth inhibition: 50000 nM
Beside the measured number, compound 3's estimate is 2.5-fold (0.40 log units) below it, within the range that was stated.
By their numbers in this assay, from the lowest: compound 2; then compounds 1 and 3 (each within the scatter of the next).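

In this assay, losing 4-hydroxy-3-nitrophenyl and gaining 2,4-dihydroxyphenyl gives a 5.0-fold higher number from compound 2 to compound 3 (0.70 log units; beyond the scatter), so the group at this position does alter growth inhibition, and the 4-chlorobenzyl series is weaker with 2,4-dihydroxyphenyl. The group on the sulfur behaves differently: 4-chlorobenzyl in place of 4-bromophenyl gives no change at the digits printed from compound 1 to compound 3 (within the scatter), so that exchange shows no effect while 2,4-dihydroxyphenyl is present. Nothing available explains why either exchange has the outcome it does.

The two groups differ in several atoms, so the nitro group and the second hydroxyl cannot be separated as the source of the step. Going by these compounds, a plain 4-hydroxyphenyl or a 4-hydroxy-3-aminophenyl at this position could help separate them, and whether 4-bromophenyl on the sulfur matches 4-chlorobenzyl alongside 4-hydroxy-3-nitrophenyl also remains open.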